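A few compounds are considered here, and "the series" means these few. Any claim that something is new, unique, unknown or untested is made for them only; others in the source may bear on it.

In a functional assay on SK-MEL-2 cells (Homo sapiens) for cytotoxicity, read by sulforhodamine B assay, with a stated time of 48 h; a lower number here means a stronger inhibitor of growth, a higher number a weaker inhibitor of growth:

compound 1, `ClCc1ccc(Cn2cnc3c(Cl)ncnc32)cc1`: > 100000 nM, a limit of the assay, not a number
compound 2, `Nc1nc(Cl)c2ncn(Cc3ccc(CCl)cc3)c2n1`: 28800 nM
compound 3, `ClCc1ccccc1Cn1cnc2c(Cl)ncnc21`: 18200 nM

Compound 1 and compound 2 differ by amino in place of hydrogen on an aromatic carbon, and the change gave an at least 3.4-fold lower number from compound 1 to compound 2 (0.54 log units; beyond the scatter). The size of that step is known only as a bound, because the starting value is the limit (the limit of > 100000 nM in this assay, at which 1 of the 3 values shown sits). Compound 3 carries a different core; the difference between the two cores is not broken down here. Compound 4, `Nc1nc(Cl)c2ncn(Cc3ccccc3CCl)c2n1`, is not yet measured. It differs from compound 3 by amino in place of hydrogen on an aromatic carbon, the same change as from compound 1 to compound 2. For compound 4 the expected step is a 3.6-fold lower number from compound 3 to compound 4 (0.56 log units; beyond the scatter), set against an at least 3.4-fold lower number from compound 1 to compound 2 (0.54 log units; beyond the scatter) and resting on compound 3 at 18200 nM as the start. Compound 4 is therefore estimated at 5000 nM, with 1500 nM to 15000 nM as the expected span.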

Compound 4, concentration for total growth inhibition: 81300 nM
For compound 4 the middle estimate is 16-fold (1.21 log units) below the measured one, outside the stated range (above it).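

In this assay, amino in place of hydrogen on an aromatic carbon gave a 4.5-fold higher number from compound 3 to compound 4 (0.65 log units; beyond the scatter). Set beside the earlier step, the same change runs in opposite directions on the two cores, so it does not carry from one to the other in this pair of cores: the same change on two cores in this assay, an at least 3.4-fold lower number (0.54 log units; beyond the scatter) from compound 1 to compound 2 and a 4.5-fold higher number (0.65 log units; beyond the scatter) from compound 3 to compound 4, at least 15-fold (1.19 log units) apart, beyond the scatter of two such steps

Two pairs give no rule for any other core and no reason for the reversal, and the earlier step is only a bound, with compound 1 standing at a limit of the assay: the limit of > 100000 nM in this assay, at which 1 of the 4 values shown sits.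

Still open, as far as these compounds go, is whether a methylamino or a methoxy group on that aromatic carbon would follow amino on either core. A third core carrying the same change would show which of the two directions is the more common.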